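Ring Halogen Pattern Change on a Naphthylamide Potassium Channel Binder

The source may report more compounds than this note shows. Statements on the series, on what has been measured and on what is new or still open speak of the compounds shown alone.

Measured compounds:
- compound 1, `O=C(Nc1c(C(O)(C(F)(F)F)C(F)(F)F)ccc2ccccc12)c1ccc(Br)cc1`: 47 nM
- compound 2, `O=C(Nc1c(C(O)(C(F)(F)F)C(F)(F)F)ccc2ccccc12)c1ccc(I)cc1`: 154 nM

Among the compounds with values here, in an assay on LtK cells with ATP-sensitive inward rectifier potassium channel 11 (Homo sapiens) as the target (on this read-out higher numbers stand for an effect only at larger amounts of compound and lower numbers for an effect already at smaller amounts), compound 2 gives the highest number of the two values; the only other number is that of compound 1, and a 3.3-fold higher number from compound 1 to compound 2 (0.52 log units; beyond the scatter). Compound 3, `O=C(Nc1c(C(O)(C(F)(F)F)C(F)(F)F)ccc2ccccc12)c1cccc(Cl)c1Cl`, has not yet been measured. It differs from compound 2 in one place: 2,3-dichlorophenyl in place of 4-iodophenyl on a carbonyl carbon. Within the data shown here, the single measured step bears on it only loosely, since it swaps one halogen for another while the ring substitution stays the same; it was modest in size. Among the measured compounds shown here, no measured pair shows what happens when the halogen pattern on that ring is rearranged, so the direction of the change is open. The expectation is therefore a step of no more than modest size in this assay, a 1.5-fold lower number from compound 2 to compound 3 (0.19 log units; within the scatter), with wide uncertainty. Compound 3 is estimated at 100 nM, in the range 25 nM to 400 nM.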

Compound 3, half-maximal effective concentration: > 10000 nM
Compound 3 gave a limit, no number; the forecaster's own chance of this, stated with the estimate: 5%; at least 100-fold (2.00 log units) between middle value and limit.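

In this assay compound 3 gives > 10000 nM, which is a limit of the assay and not a number. Putting 2,3-dichlorophenyl on the carbonyl carbon in place of the earlier groups gives an at least 64-fold higher number from compound 2 to compound 3 (1.81 log units; beyond the scatter) and an at least 210-fold higher number from compound 1 to compound 3 (2.32 log units; beyond the scatter), both much larger than the change seen on swapping one halogen for another, a 3.3-fold higher number from compound 1 to compound 2 (0.52 log units; beyond the scatter). Among these three compounds, then, the 4-bromophenyl and 4-iodophenyl groups leave a measurable effect on this carbonyl carbon, whereas the 2,3-dichlorophenyl group does not give one within the range of the assay.

This single change alters both the halogen and the pattern on the ring, so the compounds shown cannot separate the two. On these data alone, how a ring with a single chlorine would behave remains open, as does the outcome for a ring carrying an amine or a carboxylic acid instead of a halogen.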